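Methyl-for-hydrogen step in an inactive amide series

This account rests on a few compounds, and the source may have more. Where it says the series, first, only, none or still open, it means among the compounds named here.

Measured so far:
compound 1 `CC(C)[C@H](NC(=O)CNC(=O)c1cn(CC(=O)NOCc2ccccc2)c2ccccc12)C(=O)O` — in a functional assay on RAW264.7 cells (Mus musculus) for inhibition, read by microscopy and resazurin assay, with a stated time of 72 h (a higher number here means a weaker inhibitor, a lower number a stronger inhibitor), compound 1 gives > 128000 nM
compound 2 `CC(C)[C@H](NC(=O)[C@H](C)NC(=O)c1cn(CC(=O)NOCc2ccccc2)c2ccccc12)C(=O)O` — in this assay compound 2 gives > 128000 nM
compound 3 `CC(C)[C@H](NC(=O)CNC(=O)c1ccn(CC(=O)NOCc2ccccc2)c1)C(=O)O` — in this assay compound 3 gives > 128000 nM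

Every value in this assay is a limit of the assay and not a number. The value of compound 1 is such a limit. The value of compound 2 is likewise a limit. The value of compound 3 is a limit as well. Among the measured compounds shown here, the only single-point change among the measured compounds is methyl in place of hydrogen on a saturated chain carbon bound to an amide-type nitrogen and a carbonyl carbon, and the step that the two limits leave unreadable from compound 1 to compound 2 cannot be read because both ends sit at the limit of > 128000 nM in this assay, at which 3 of the 3 values shown sit. The difference between the core of compound 1 and the core of compound 3 is not broken down here.

Compound 4 `CC(C)[C@H](NC(=O)[C@H](C)NC(=O)c1ccn(CC(=O)NOCc2ccccc2)c1)C(=O)O` is not yet measured. It differs from compound 3 by methyl in place of hydrogen on a saturated chain carbon bound to an amide-type nitrogen and a carbonyl carbon, the same change that leads from compound 1 to compound 2, at a place described in identical words. Since compound 3 gives > 128000 nM, and the same change on compound 1 left compound 2 at the limit of > 128000 nM in this assay, at which 3 of the 3 values shown sit, the step that the limit leaves unreadable from compound 3 to compound 4 is expected to be small or unreadable. Compound 4 is therefore estimated at 200000 nM, with a range from 60000 nM to 700000 nM, and most likely the assay will again report only a limit.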

Compound 4, half-maximal inhibitory concentration: > 128000 nM
Compound 4 was reported as a limit (the forecaster's own chance of this, stated with the estimate: 85%); the middle value is on the limit's open side.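

No new step can be read between compound 3 and compound 4, because the values of both are limits of the assay and not numbers: (the limit of > 128000 nM in this assay, at which 4 of the 4 values shown sit). The compounds shown leave open whether methyl in place of hydrogen on this saturated chain carbon has any effect in this assay and whether any compound of this series gives a numerical value there.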